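Para-Aryl Pyridine Amides Against Prostate Cancer Cells

This account rests on a few compounds, and the source may have more. Where it says the series, first, only, none or still open, it means among the compounds named here.

Measured compounds:
- compound 1 `O=C(Nc1ccc(Oc2ccnc3[nH]ccc23)cc1)c1ccc(-c2ccc(Cl)cc2)cn1`: > 10000 nM
- compound 2 `Cc1ccc(-c2ccc(C(=O)Nc3ccc(Oc4ccnc5[nH]ccc45)cc3)nc2)cc1`: > 10000 nM
- compound 3 `COc1ccc(-c2ccc(C(=O)Nc3ccc(Oc4ccnc5[nH]ccc45)cc3)nc2)cc1`: > 10000 nM

Three compounds share the core of compound 1 and differ only in the group on the distal phenyl ring. In a functional assay on PC-3 cells (Homo sapiens) for cytotoxicity, read by MTT assay, with a stated time of 72 h (on this read-out higher numbers stand for weaker inhibition and lower numbers for stronger inhibition), compound 1 reaches only the limit of the assay, giving > 10000 nM. Compound 2 likewise gives only a limit, > 10000 nM. Compound 3 also stands at a limit, with > 10000 nM. Because all three values sit at the limit of > 10000 nM in this assay, at which 3 of the 3 values shown sit, the steps a step that the two limits leave unreadable from compound 1 to compound 2, a step that the two limits leave unreadable from compound 1 to compound 3 and a step that the two limits leave unreadable from compound 2 to compound 3 cannot be sized, and compound 3 cannot be placed against the others beyond the fact that it shares their limit.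

Compound 4 `O=C(Nc1ccc(Oc2ccnc3[nH]ccc23)cc1)c1ccc(-c2ccc(F)cc2F)cn1` is the next compound in the series. It differs from compound 3 by 2,4-difluorophenyl in place of 4-methoxyphenyl on an aromatic carbon. Within the data shown here, none of the measured steps can be read, so no direction for this change can be drawn from them. With all three neighbours at the limit, compound 4 is expected to remain weak, with an expected step that the limit leaves unreadable from compound 3 to compound 4. The value of compound 4 in this assay is estimated at 15000 nM, within a range from 3000 nM to 60000 nM.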

Compound 4, half-maximal inhibitory concentration: > 10000 nM
Compound 4: no number, only a limit; the forecaster's own chance of this, stated with the estimate: 75%; the middle value lies beyond the limit too.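

In this assay compound 4 gives > 10000 nM, again only a limit. The steps from compounds 1, 2 and 3 to compound 4 cannot be read, because all four compounds share one limit: the limit of > 10000 nM in this assay, at which 4 of the 4 values shown sit.

The compounds shown leave open whether these four groups differ in effect at all.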